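The compounds below may be only part of what the source reports. "The series", "measured", "known", "first", "only" and "open" are said of these compounds alone.

In a functional assay on KOPN-8 cells (Homo sapiens) for antiproliferative activity, with a stated time of 72 h (a lower number here means that less compound is needed, a higher number that more compound is needed for the effect), compound 1 `COC(=O)c1cc(=O)c2c(OC)cc(OC)cc2[nH]1` gives > 34400 nM, which is a limit of the assay rather than a number. Compound 2 `COc1ccc(-c2cc(=O)c3c(OC)cc(OC)cc3n2S(=O)(=O)c2cccc([N+](=O)[O-])c2)cc1`, which carries an aryl sulfonyl group on an aromatic nitrogen of the shared core, also reaches only a limit, > 39600 nM. Compound 3 `COc1ccc(-c2cc(=O)c3c(OC)cc(OC)cc3n2S(=O)(=O)c2ccc(C)c([N+](=O)[O-])c2)cc1` stands at > 51700 nM, again a limit and not a measured value. All three readings are limits, so compound 3 stands together with compound 1 and compound 2 at the edge of what this assay can report, as the limit of > 34400 nM in this assay, at which 1 of the 3 values shown sits, the limit of > 39600 nM in this assay, at which 1 of the 3 values shown sits, and the limit of > 51700 nM in this assay, at which 1 of the 3 values shown sits, show. Among the compounds with values here, the one step between measured compounds, a step that the two limits leave unreadable from compound 2 to compound 3, lies between two limits and cannot be sized. Compound 4 `COc1ccc(-c2cc(=O)c3c(OC)cc(OC)cc3n2S(=O)(=O)c2ccc(Cl)cc2)cc1` is the next member and has not yet been measured. The change 4-chlorophenyl in place of 4-methyl-3-nitrophenyl on a sulfonyl sulfur exchanges one aryl group on the sulfonyl sulfur for another. Within the data shown here, no measured step offers a readable size, so for compound 4 the step of an at least 1.1-fold lower number from compound 3 to compound 4 (0.06 log units; that floor lies within the scatter) is expected to be none beyond the scatter. Compound 4 is therefore estimated at 45000 nM in this assay, with a range from 12000 nM to 150000 nM.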

Compound 4, half-maximal effective concentration: > 34400 nM
Compound 4 gave a limit, no number (the forecaster's own chance of this, stated with the estimate: 80%); the middle value lies beyond the limit too.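

Compound 4 gives only a limit, as do compound 2 and compound 3, so the steps from compound 3 to compound 4 and from compound 2 to compound 4 cannot be read. The compounds shown leave open whether any aryl group on the sulfonyl sulfur yields an actual number in this assay.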